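Arylpiperazine amides of a succinimide core: maximal electroshock notes

The source may hold more compounds than are shown below. What is called first, only, known or untested is meant among the compounds shown, and "the series" means these compounds.

Measured:
- compound 1, `CC1(c2ccccc2)CC(=O)N(CC(=O)N2CCN(c3ccccc3F)CC2)C1=O`: 100 mg/kg
- compound 2, `CC1(c2ccccc2)CC(=O)N(CC(=O)N2CCN(c3ncccn3)CC2)C1=O`: "not active" (no number reported)

In a functional assay on the whole organism (strain CD-1) with Mus musculus as the target, in the maximal electroshock model, with a stated time of 0.5 h (a lower number here means that less compound is needed, a higher number that more compound is needed for the effect), compound 1 gives 100 mg/kg. In this assay compound 2 is reported as "not active" (no number reported), so compound 2 stands with no number at all in this assay; only compound 1 carries a minimum effective dose here.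

Compound 3, `CC1(c2ccccc2)CC(=O)N(CC(=O)N2CCN(c3cccc(C(F)(F)F)c3)CC2)C1=O`, has not been measured. It differs from compound 2 by 3-(trifluoromethyl)phenyl in place of pyrimidin-2-yl on an amine nitrogen in a ring.

Since compound 2 gave no measurable effect while compound 1, also bearing a phenyl group on the ring nitrogen, gave 100 mg/kg, a step toward a lower number, beyond the scatter of this assay, is expected from compound 2 to compound 3. For compound 3 the minimum effective dose is estimated at 100 mg/kg, within 30 mg/kg to 300 mg/kg.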

Compound 3, minimum effective dose: 300 mg/kg
The estimate for compound 3 lay 3.0-fold (0.48 log units) below the measured number, within the range that was stated.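

In this assay, going by these compounds alone, the dose still shifts when one carbon-only aromatic ring on this amine nitrogen in a ring replaces another: 3-(trifluoromethyl)phenyl in place of 2-fluorophenyl gives a 3.0-fold higher number from compound 1 to compound 3 (0.48 log units; beyond the scatter) as the first readable step at this position. Within the data shown here, compound 3 carries a number, as compound 1 does, whereas compound 2, with pyrimidin-2-yl, has none, so no step to or from compound 2 can be read. Nothing at hand explains the step.

Still open, going by these compounds, is whether the trifluoromethyl group or the fluorine sets this difference, since the two groups also sit at different ring positions. Plain phenyl and 2-(trifluoromethyl)phenyl on the same nitrogen would separate those two changes.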